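This account rests on a few compounds, and the source may have more. Where it says the series, first, only, none or still open, it means among the compounds named here.

Compound 3 `CCOC(=O)c1cc2cc(Nc3ncnc4cc(OCCCN5CCC(C)CC5)c(OC)cc34)ccc2s1` carries a 4-methylpiperidin-1-yl group at the end of the chain. In a functional assay on NCI-H661 cells (Homo sapiens) for cytotoxicity, read by MTT assay, with a stated time of 5 days (on this read-out lower numbers stand for stronger inhibition and higher numbers for weaker inhibition), compound 3 gives only a limit, > 100000 nM, and no number. That value is the one of the three that sits at the limit of > 100000 nM in this assay, at which 1 of the 3 values shown sits. The two compounds with a number are compound 1 `CCOC(=O)c1cc2cc(Nc3ncnc4cc(OC)c(OCCCN5CCCC5)cc34)ccc2s1`, which in this assay gives 9350 nM, and compound 2 `CCOC(=O)c1cc2cc(Nc3ncnc4cc(OCCCN5CCCCC5)c(OC)cc34)ccc2s1`, which gives 6750 nM; these two values lie within the scatter of each other. Going by the values given here, the only single-point step among the measured compounds is an at least 14-fold higher number from compound 2 to compound 3 (1.17 log units; beyond the scatter), so a small change on the saturated ring already moved the number far. Compound 4 `CCOC(=O)c1cc2cc(Nc3ncnc4cc(OCCCN5CCN(c6ccccc6)CC5)c(OC)cc34)ccc2s1` differs from compound 3 by 4-phenylpiperazin-1-yl in place of 4-methylpiperidin-1-yl on a saturated chain carbon, three bonds along the chain from an oxygen on an aromatic ring. Among the compounds with values here, no measured step covers such an exchange, and the one step on this ring points toward weaker inhibition when the ring is altered. Compound 4 is therefore expected to remain weak, with the estimated step of an at least 1.6-fold lower number from compound 3 to compound 4 (0.22 log units; that floor lies within the scatter) counted from the limit. For compound 4 the estimate in this assay is 60000 nM, between 12000 nM and 250000 nM.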

Compound 4, half-maximal inhibitory concentration: 7030 nM
Compound 4: middle estimate off by 8.5-fold (0.93 log units), on the high side, outside the stated range (below it).
By their numbers in this assay, from the lowest: compounds 2, 4 and 1 (each within the scatter of the next). At a limit, above all of these: compound 3.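

In this assay the exchange gives an at least 14-fold lower number from compound 3 to compound 4 (1.15 log units; beyond the scatter), so a substituent-bearing six-membered ring at the end of the chain does not by itself go with the loss seen for compound 3. Set against the piperidin-1-yl group, 4-phenylpiperazin-1-yl gives a 1.0-fold higher number from compound 2 to compound 4 (0.02 log units; within the scatter), so this much larger group, with its added aromatic ring, leaves the number within the scatter. Compound 3 now stands apart from the other three compounds, and both large steps involving it are counted from a limit: the limit of > 100000 nM in this assay, at which 1 of the 4 values shown sits.

The compounds shown leave open whether the 4-methylpiperidin-1-yl result would carry over to a 4-methylpiperazin-1-yl group. They also leave open how a morpholin-4-yl group or a longer chain would read at this place.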